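Pyrimidinyl sulfonamide as a variant of an oxazolyl parent

The source may report more compounds than this note shows. Statements on the series, on what has been measured and on what is new or still open speak of the compounds shown alone.

Measured compounds:
compound 1 `Cc1cc(NS(=O)(=O)c2ccc(Nc3nncc4ccccc34)cc2)no1`, 33 nM
compound 2 `COc1ccc(NC(=S)NNc2nncc3ccccc23)cc1`, 47 nM
compound 3 `C(=C/c1ccccc1)\C(=N\Nc1nncc2ccccc12)c1ccccc1`, 3.9 nM

Of the compounds shown here, three sharing a core have been tested in a functional assay on UO-31 cells (Homo sapiens) for antiproliferative activity, read by sulforhodamine B assay, with a stated time of 72 h; a lower number here means a stronger inhibitor, a higher number a weaker inhibitor. Compound 1 gives 33 nM, and compound 2 gives 47 nM; these two numbers lie within the usual scatter of each other, so no order between them can be read. Compound 3, by contrast, gives 3.9 nM, a clearly lower number than compound 1, beyond the scatter. Compound 1 thus stands at the second highest number of the three.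

Compound 4 `O=S(=O)(Nc1ncccn1)c1ccc(Nc2nncc3ccccc23)cc1` is the sulfonamide of compound 1 with one replacement: pyrimidin-2-yl in place of 5-methyl-1,2-oxazol-3-yl on a sulfonamide nitrogen. The difference, read one bond further out, is (5-methyl-1,2-oxazol-3-yl)amino to (pyrimidin-2-yl)amino, with the count of donors and acceptors unchanged. Going by the values given here, no measured pair shows what such a swap does here. Compound 4 is therefore expected to give a number close to that of compound 1, with the step of a 1.2-fold higher number from compound 1 to compound 4 (0.08 log units; within the scatter) estimated to stay within the scatter. For compound 4 the estimate in this assay is 40 nM, with a range from 15 nM to 110 nM.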

Compound 4, half-maximal inhibitory concentration: 23 nM
Compound 4: middle estimate off by 1.7-fold (0.24 log units), on the high side, within the range that was stated.
By their numbers in this assay, from the lowest: compound 3; then compounds 4, 1 and 2 (each within the scatter of the next, the first and the last beyond it).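

On a sulfonamide nitrogen, pyrimidin-2-yl in place of 5-methyl-1,2-oxazol-3-yl gives in this assay the step of a 1.4-fold lower number from compound 1 to compound 4 (0.16 log units; within the scatter) and, with this step inside the usual scatter, no order can be read between the two compounds. The earlier compounds shown here offered no pair differing in one place, whereas this pair shows that a six-membered aromatic ring with 2 hetero atoms can take the place of a five-membered one here without a shift that stands clear of the scatter. No measurement given here bears on why the two compounds match so closely.

As far as these compounds go, it remains open whether this nitrogen would accept something other than an aromatic ring, such as a methyl group, an amine-bearing chain or a carboxylic acid. Compound 3 differs from compound 1 in more than one place, so the compounds shown do not tell which part of it goes with its lower number.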